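Swapping the Methoxyphenyl Group for a Benzodioxin Ring

This account rests on a few compounds, and the source may have more. Where it says the series, first, only, none or still open, it means among the compounds named here.

Going by the values given here, in an assay on isolated protein for binding affinity to melanin-concentrating hormone receptor 1 (Homo sapiens) (on this read-out lower numbers stand for stronger inhibition and higher numbers for weaker inhibition), compound 2 `COc1ccc(-c2cc3ncn([C@H]4CCN(C(=O)N(C)[C@H]5CCN(C)C5)C4)c(=O)c3s2)cc1` gives 21 nM, the lower of the two numbers known so far, while compound 1 `Cc1ccc(-c2cc3ncn([C@H]4CCN(C(=O)N(C)[C@H]5CCN(C)C5)C4)c(=O)c3s2)c(C)c1` gives 49 nM. Among the compounds with values here, the single measured step, a 2.3-fold lower number from compound 1 to compound 2 (0.37 log units; beyond the scatter), involves a different exchange of aromatic groups and so bears only loosely on what follows. Compound 3 `CN1CC[C@H](N(C)C(=O)N2CC[C@H](n3cnc4cc(-c5ccc6c(c5)OCCO6)sc4c3=O)C2)C1` differs from compound 2 by 2,3-dihydro-1,4-benzodioxin-6-yl in place of 4-methoxyphenyl on an aromatic carbon. Within the data shown here, no measured step shows this particular exchange, so the expected step is small, a 1.2-fold higher number from compound 2 to compound 3 (0.08 log units; within the scatter), hardly beyond the scatter. The estimate for compound 3 in this assay is therefore 25 nM, within 10 nM to 60 nM.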

Compound 3, inhibition constant: 143 nM
Estimate against measurement, compound 3: 5.7-fold (0.76 log units) below; measured number above the stated range.
By their numbers in this assay, from the lowest: compound 2; then compound 1; then compound 3.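

Going by these compounds alone, at this position, next to the ring sulfur, the exchange matters far more than the earlier compounds hinted: this assay shows a 6.8-fold higher number from compound 2 to compound 3 (0.83 log units; beyond the scatter) for the benzodioxin ring. The same ring also falls behind 2,4-dimethylphenyl, with a 2.9-fold higher number from compound 1 to compound 3 (0.47 log units; beyond the scatter) across that exchange, so it gives the highest number of the three aryl groups. No evidence at hand says why the number rises.

Open, from the compounds shown here alone, is whether the second ring oxygen or the closed ring drives the change, a question 3,4-dimethoxyphenyl would address. Going by these compounds, how an amine on the phenyl ring would fare also remains unknown.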